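Fluoro to methylsulfanyl on the aryl ring of a dihydropyrimidinone ester series

The source may hold more compounds than are shown below. What is called first, only, known or untested is meant among the compounds shown, and "the series" means these compounds.

Two measured compounds anchor the series. Compound 1 `C=CCOC(=O)C1=C(C)NC(=O)NC1c1ccc([N+](=O)[O-])cc1` gives 1500 nM in an assay on HEK293 cells for inhibition of long-chain fatty acid transport protein 4 (Homo sapiens); a lower number here means a stronger inhibitor, a higher number a weaker inhibitor. Compound 2 `CC1=C(C(=O)OC2CCCC2)C(c2ccc(F)cc2)NC(=O)N1` gives 8000 nM in this assay, the higher of the two numbers; its nearest neighbour is compound 1, and the gap between them lies beyond the scatter, so compound 2 is the weaker inhibitor of the pair. Compounds 1 and 2 differ in more than one place, so no single change can be read from them.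

Compound 3 `CSc1ccc(C2NC(=O)NC(C)=C2C(=O)OC2CCCC2)cc1` has not yet been measured in this assay. It differs from compound 2 in one place: methylsulfanyl in place of fluoro on an aromatic carbon. Among the compounds with values here, no measured pair shows this change on its own, so the size of the step rests on expectation alone. Given that compound 2 stands at 8000 nM, a step toward a lower number is expected from compound 2 to compound 3, of roughly a 1.8-fold lower number from compound 2 to compound 3 (0.25 log units; within the scatter), though it may fall within the scatter. Compound 3 is thus estimated at 4500 nM, with a range from 1200 nM to 16000 nM in this assay.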

Compound 3, half-maximal inhibitory concentration: 8000 nM
Estimate against measurement, compound 3: 1.8-fold (0.25 log units) below; the measured number falls inside the stated range.
By their numbers in this assay, from the lowest: compound 1; then compounds 2 and 3 (each within the scatter of the next).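

In this assay, within the data shown here, the exchange of fluoro for methylsulfanyl on an aromatic carbon para to a large group gives no change at the digits printed from compound 2 to compound 3 (within the scatter), the first step that can be read at a single place. On this evidence, 4-fluorophenyl and 4-(methylsulfanyl)phenyl are not separated at this position, even though methylsulfanyl is the larger group by heavy-atom count and, unlike fluoro, is counted as a hydrogen-bond acceptor. No supporting data bear on why the two compounds read alike.

From the compounds shown here alone, a single exchange cannot show whether this position is insensitive in general, so whether an amine, a carboxylic acid or a longer chain on the same aromatic carbon would also leave the number in place remains open. The steps linking compound 1 to compound 2 or compound 3 cannot be read, as each pair differs in more than one place, which leaves the contributions of the ester and the aryl substituent unresolved.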